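This account rests on a few compounds, and the source may have more. Where it says the series, first, only, none or still open, it means among the compounds named here.

Compound 1 `Nc1cn(COCCO)c(=O)[nH]c1=O` carries an amino group on the shared core. In a functional assay on Vero cells (Chlorocebus sabaeus) for cytotoxicity, read by MTT assay (a lower number here means that less compound is tolerated, a higher number that more compound is tolerated), compound 1 gives > 497000 nM, which is a limit of the assay rather than a number. Compound 2 `CCc1cn(COCCO)c(=S)[nH]c1=O` differs from compound 1 in more than one place. In this assay compound 2 gives > 478000 nM, again a limit of the assay. Among the measured compounds shown here, compound 1 therefore stands at a limit, and the only other value shown is a limit as well, as the limit of > 497000 nM in this assay, at which 1 of the 2 values shown sits, and the limit of > 478000 nM in this assay, at which 1 of the 2 values shown sits, record.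

Compound 3 `O=c1[nH]c(=O)n(COCCO)cc1CO` has not yet been measured. It differs from compound 1 in a single place: hydroxymethyl in place of amino on an aromatic carbon, in words hydroxymethyl in place of amino on an aromatic carbon. For the measured compounds named here, no step between two measured compounds is available here, and both values shown are limits, so no direction can be read from the numbers. The step that the limit leaves unreadable from compound 1 to compound 3 is expected to stay within the scatter, and most likely only a limit will again be reported. Compound 3 is expected to give 500000 nM in this assay, between 200000 nM and 2000000 nM.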

Compound 3, half-maximal cytotoxic concentration: > 476000 nM
Compound 3 was reported as a limit; the forecaster's own chance of this, stated with the estimate: 85%; the middle value lies beyond the limit too.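

Compound 1 and compound 3 both stand as limits in this assay, so the step with hydroxymethyl in place of amino cannot be read. The compounds shown leave open whether any of them has a half-maximal cytotoxic concentration that can be stated as a number in this assay, and whether that exchange changes it at all.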